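Methoxy for fluoro on the aryl of compound 1

A few compounds are considered here, and "the series" means these few. Any claim that something is new, unique, unknown or untested is made for them only; others in the source may bear on it.

Going by the values given here, compound 1 `O=C(Nc1nc2ccc(F)cc2s1)c1cn(-c2ccccc2)nc1-c1ccc(F)cc1` gives 6650 nM in a functional assay on A549 cells (Homo sapiens) for cytotoxicity, read by MTT assay, with a stated time of 72 h (on this read-out lower numbers stand for stronger inhibition and higher numbers for weaker inhibition), the highest of the two numbers measured so far. Its nearest neighbour is compound 2 `O=C(Nc1nc2ccc(Cl)cc2s1)c1cn(-c2ccccc2)nc1-c1ccc(F)cc1`, which gives 3870 nM in this assay. That step reads a 1.7-fold lower number from compound 1 to compound 2 (0.24 log units; within the scatter). Compound 3 `COc1ccc(-c2nn(-c3ccccc3)cc2C(=O)Nc2nc3ccc(F)cc3s2)cc1` is not yet measured; it differs from compound 1 by methoxy in place of fluoro on an aromatic carbon. Among the compounds with values here, the only measured step touching a substituent of this kind on an aromatic carbon is the one from compound 1 to compound 2, and it stays within the scatter, though it concerns a different entering group. Within the data shown here, no measured step shows methoxy in place of fluoro at this place. For compound 3 the expected step is therefore a 1.1-fold lower number from compound 1 to compound 3 (0.04 log units; within the scatter), nothing beyond the scatter. Compound 3 is estimated at 6000 nM, with a range from 2000 nM to 18000 nM.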

Compound 3, half-maximal inhibitory concentration: 7560 nM
Compound 3: middle estimate off by 1.3-fold (0.10 log units), on the low side, and the stated range covers the measured number.
By their numbers in this assay, from the lowest: compounds 2, 1 and 3 (each within the scatter of the next).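

In this assay, going by these compounds alone, the change from 4-fluorophenyl to 4-methoxyphenyl gives a 1.1-fold higher number from compound 1 to compound 3 (0.06 log units; within the scatter) and provides the first reading at this place, on an aromatic carbon para to a large group; the earlier step concerned a different substituent exchange. Methoxy has more heavy atoms than fluoro and brings a hydrogen-bond acceptor, yet this exchange produces no difference beyond the scatter on this read-out. No evidence is available to explain this result.

On these data alone, whether an amine, a carboxylic acid or a longer alkoxy chain at this place would move the number beyond the scatter remains open. Also open, as far as these compounds go, is whether methoxy would give a similar result when combined with the chloro group of compound 2.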